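Trading benzothiophene for benzofuran in compound 4

This account rests on a few compounds, and the source may have more. Where it says the series, first, only, none or still open, it means among the compounds named here.

In a functional assay on DU-145 cells (Homo sapiens) for inhibition, read by trypan blue exclusion, with a stated time of 72 h (a higher number here means a weaker inhibitor, a lower number a stronger inhibitor), compound 3 `Cn1c(=O)c(S(=O)(=O)c2ccc(F)cc2F)cc2cnc(Nc3ccc4sccc4c3)nc21` gives 500 nM. That is within the usual scatter of compound 2 `Cn1c(=O)c(S(=O)(=O)c2ccc(F)cc2F)cc2cnc(Nc3cccc4[nH]ccc34)nc21`, which gives 750 nM, while compound 1 `Cn1c(=O)c(S(=O)(=O)c2ccc(F)cc2)cc2cnc(Nc3ccc4occc4c3)nc21` stands clearly apart at 5000 nM. Compound 4 `Cn1c(=O)c(S(=O)(=O)c2ccc(F)cc2F)cc2cnc(Nc3ccc4occc4c3)nc21` puts 1-benzofuran-5-yl in place of the 1-benzothiophen-5-yl of compound 3, on a nitrogen on an aromatic ring: 1-benzofuran-5-yl in place of 1-benzothiophen-5-yl on a nitrogen on an aromatic ring. Going by the values given here, only one measured step changes a group at this place, a 1.5-fold lower number from compound 2 to compound 3 (0.18 log units; within the scatter), and it stays within the scatter. Compound 1 also carries 1-benzofuran-5-yl, but it is not otherwise identical to compound 4, so it isolates nothing. The expected change is therefore none beyond the scatter, a 1.4-fold higher number from compound 3 to compound 4 (0.15 log units; within the scatter). For compound 4 the estimated value is 700 nM, with an expected range of 250 nM to 2500 nM.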

Compound 4, half-maximal inhibitory concentration: 15000 nM
Compound 4: middle estimate off by 21-fold (1.33 log units), on the low side, and the stated range ends below it.
By their numbers in this assay, from the lowest: compounds 3 and 2 (each within the scatter of the next); then compound 1; then compound 4.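

Sulfur and oxygen are the only difference between the groups at this place, yet this assay gives a 30-fold higher number from compound 3 to compound 4 (1.48 log units; beyond the scatter) as a large loss of inhibition. 1-Benzofuran-5-yl also compares poorly with 1H-indol-4-yl, with a 20-fold higher number from compound 2 to compound 4 (1.30 log units; beyond the scatter) as a large step, and fluoro in place of hydrogen on an aromatic carbon gives a 3.0-fold higher number from compound 1 to compound 4 (0.48 log units; beyond the scatter) as a modest further loss. Nothing measured here explains these steps.

From the compounds shown here alone, whether 1-benzothiophen-5-yl keeps its lead over 1-benzofuran-5-yl without that added fluoro remains open. So does the effect of an amine or a carboxylic acid on the 1-benzothiophen-5-yl group.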